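The compounds below may be only part of what the source reports. "The series", "measured", "known", "first", "only" and "open" are said of these compounds alone.

In an ADME assay on microsomes from liver (Mus musculus) for metabolic stability, read by LC-MS, with a stated time of 30 min, tested at 1 uM (a lower number here means that less of the compound is left, a higher number that more of the compound is left), compound 3 (`O=C(NCc1ccc(S(=O)(=O)c2cc(F)cc(F)c2)cc1)c1cc2cnccc2[nH]1`) gives 63%, the highest of the three numbers, ahead of compound 2 (`O=C(NCc1ccc(S(=O)(=O)c2cccc(F)c2)cc1)c1cc2cnccc2[nH]1`) at 44% and compound 1 (`O=C(NCc1ccc(S(=O)(=O)c2ccccc2)cc1)c1cc2ccncc2s1`) at 21%. Compound 4 (`O=C(NCc1ccc(S(=O)(=O)c2ccccc2)cc1)c1cc2cnccc2[nH]1`) keeps the core of compound 3 and differs as follows: phenyl in place of 3,5-difluorophenyl on a sulfonyl sulfur. Within the data shown here, the only measured step that bears on this is a number 19 percentage points higher from compound 2 to compound 3 (beyond the scatter), modest but beyond the scatter, with fluoro in place of hydrogen on an aromatic carbon. The new change runs the opposite way and removes both fluoro groups, so a larger fall is expected in this assay. The expected step is a number 34 percentage points lower from compound 3 to compound 4 (beyond the scatter). For compound 4 the estimated value is 29%, with an expected range of 14% to 46%.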

Compound 4, percent of the compound remaining: 54%
Beside the measured number, compound 4's estimate is 25 percentage points below it; the whole stated range lies below it.
By their numbers in this assay, from the lowest: compound 1; then compounds 2, 4 and 3 (each within the scatter of the next, the first and the last beyond it).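

In this assay, among these compounds, removing both fluoro groups gives a number 9 percentage points lower from compound 3 to compound 4 (within the scatter) and removing the single fluoro gives a number 10 percentage points higher from compound 2 to compound 4 (within the scatter) so the plain phenyl on a sulfonyl sulfur cannot be told apart from either fluorinated ring, even though a number 19 percentage points higher from compound 2 to compound 3 (beyond the scatter) remains the one step among the three that is beyond the scatter. The change on the carbonyl carbon gives far more, with a number 33 percentage points higher from compound 1 to compound 4 (beyond the scatter) in this series. Nothing available explains these steps.

From the compounds shown here alone, whether a methoxy or a nitrile on this phenyl would behave like fluoro remains open. So does whether fluoro on the phenyl would count for anything on the core of compound 1.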